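Piperidine nitrogen carbamate swapped for an aryl group

The source may hold more compounds than are shown below. What is called first, only, known or untested is meant among the compounds shown, and "the series" means these compounds.

Measured so far in a functional assay on HEK293 cells for agonist activity at Glucose-dependent insulinotropic receptor (Homo sapiens), read by cAMP accumulation, with a stated time of 30 min; on this read-out higher numbers stand for an effect only at larger amounts of compound and lower numbers for an effect already at smaller amounts:
compound 1 `CC(C)OC(=O)N1CCC(n2ncc3cc(-c4ccc(S(C)(=O)=O)cc4F)ncc32)CC1` gives 27 nM
compound 2 `CC(C)(OC(=O)N1CCC(n2ncc3cc(-c4ccc(S(C)(=O)=O)cc4F)ncc32)CC1)C(F)F` gives 10 nM

Within the data shown here, compound 2 holds the lower of the two numbers in this assay ; its only neighbour is compound 1, with the step of a 2.7-fold lower number from compound 1 to compound 2 (0.43 log units; beyond the scatter).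

Compound 3 `CCc1cnc(N2CCC(n3ncc4cc(-c5ccc(S(C)(=O)=O)cc5F)ncc43)CC2)nc1` differs from compound 2 by 5-ethylpyrimidin-2-yl in place of (1-(difluoromethyl)-1-methylethoxy)carbonyl on an amine nitrogen in a ring. Among the measured compounds shown here, the single measured step, a 2.7-fold lower number from compound 1 to compound 2 (0.43 log units; beyond the scatter), touched only the chain of the carbamate and leaves the replacement of the whole carbamate untested. With no guide beyond that, compound 3 is estimated at 20 nM, range 4 nM to 100 nM, an expected step of a 2.0-fold higher number from compound 2 to compound 3 (0.30 log units; within the scatter) within the scatter.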

Compound 3, half-maximal effective concentration in the Glucose-dependent insulinotropic receptor assay: 4 nM
Estimate against measurement, compound 3: 5.0-fold (0.70 log units) above, within the range that was stated.
By their numbers in the Glucose-dependent insulinotropic receptor assay, from the lowest: compound 3; then compound 2; then compound 1.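

Notes on the series: the amine nitrogen in the six-membered ring does not need a carbamate, since an aromatic ring, 5-ethylpyrimidin-2-yl, can stand there and the agonist read-out still moves down, with a 2.5-fold lower number from compound 2 to compound 3 (0.40 log units; beyond the scatter) and a 6.8-fold lower number from compound 1 to compound 3 (0.83 log units; beyond the scatter). This replacement takes the series further than the chain change on the carbamate did. In a physicochemical assay for solubility, in phosphate buffer, measured as thermodynamic solubility, at pH 6.8 (on this read-out higher numbers stand for higher solubility and lower numbers for lower solubility), the same replacement gives an at least 5.6-fold higher number from compound 2 to compound 3 (0.75 log units; beyond the scatter), a step read against a limit of the assay: the limit of < 0.06 ug/mL in the physicochemical assay, at which 1 of the 2 values shown sits. In the physicochemical assay compound 2 gives < 0.06 ug/mL, which is a limit of the assay and not a number. In the physicochemical assay compound 3 gives 0.34 ug/mL.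

From the compounds shown here alone, whether a methyl, a methoxy or an amine in place of the ethyl holds the Glucose-dependent insulinotropic receptor assay remains open. So does the effect of a pyridine in place of the pyrimidine.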